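Dropping the Phenyl Ring: From Compound 2 to Compound 3

A few compounds are considered here, and "the series" means these few. Any claim that something is new, unique, unknown or untested is made for them only; others in the source may bear on it.

Of the compounds shown here, two have been tested so far in a functional assay on HL-60 cells (Homo sapiens) for cytotoxicity, read by luminescence and CellTiter-Glo, with a stated time of 3 days; a higher number here means a weaker inhibitor, a lower number a stronger inhibitor. Compound 1 `N#Cc1ccc(NC(=O)c2cc(Br)ccc2O)cc1` gives 620 nM. Compound 2 `N#Cc1ccc(NC(=O)c2cc(Cl)c(-c3ccccc3)cc2O)cc1` gives 520 nM in this assay. Of the two numbers, that of compound 2 is the lower, but its distance to compound 1 lies within the usual scatter of repeated measurements, so neither compound can be called the stronger inhibitor on this evidence.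

Compound 3 `N#Cc1ccc(NC(=O)c2cc(Cl)ccc2O)cc1` has not yet been measured. It differs from compound 2 in one place: hydrogen in place of phenyl on an aromatic carbon. Apart from this, compound 3 resembles compound 1, carrying a chloro group where compound 1 carries a bromo group.

Among the compounds with values here, no step between two measured compounds that differ in one place is available, so the effect of this change has to be inferred. Since compound 1 gives 620 nM and compound 2 gives 520 nM, and the two stand within the scatter, the step is expected to be small, a 1.3-fold higher number from compound 2 to compound 3 (0.10 log units; within the scatter), with no direction beyond the scatter. Compound 3 is therefore estimated at 650 nM, with a likely range from 300 nM to 1400 nM.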

Compound 3, half-maximal inhibitory concentration: 700 nM
Compound 3: the middle estimate sits 1.1-fold (0.03 log units) below what was measured, and the stated range covers the measured number.
By their numbers in this assay, from the lowest: compounds 2, 1 and 3 (each within the scatter of the next).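

In this assay, within the data shown here, taking the phenyl group off this aromatic carbon, which is ortho to a chloro group and meta to a hydroxy group, gives a 1.3-fold higher number from compound 2 to compound 3 (0.13 log units; within the scatter), so the first direct comparison at this position shows no effect that can be told apart from the scatter. A second direct comparison, chloro in place of bromo, gives a 1.1-fold higher number from compound 1 to compound 3 (0.05 log units; within the scatter), so these two halogens cannot be told apart on these numbers either, and a whole phenyl group and a change of halogen both leave the read-out inside the noise of the measurement. Nothing beyond these cell numbers is available to say what either group does in these compounds.

The compounds shown place only hydrogen or phenyl on this carbon, so it remains open whether an amine, a carboxylic acid or a methoxy group there would give a step beyond the scatter. All three compounds also keep the hydroxy group and the nitrile, which leaves open what a methoxy group in place of that hydroxy group, or a carboxylic acid in place of that nitrile, would do.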